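The compounds below may be only part of what the source reports. "The series", "measured", "known", "first", "only" and "open" are said of these compounds alone.

In a toxicity assay (RAW264.7 cells) for cytotoxicity, with Mus musculus as the target, read by MTT assay, with a stated time of 24 h (a lower number here means a stronger inhibitor, a higher number a weaker inhibitor), compound 1 `CCCCCCCCCC(=O)c1c(O)cc(O)c([C@@H](CC(C)C)C2=C(O)C(C)(C)C(=O)C(C)(C)C2=O)c1O` gives 5.1 ug/mL and stands level with compound 2 `CCCCCCCC(=O)c1c(O)cc(O)c([C@@H](CC(C)C)C2=C(O)C(C)(C)C(=O)C(C)(C)C2=O)c1O` at 5.1 ug/mL as the lowest of three numbers, while compound 3 `CCCCCCCCCCCCCCCC(=O)c1c(O)cc(O)c([C@@H](CC(C)C)C2=C(O)C(C)(C)C(=O)C(C)(C)C2=O)c1O` gives 17.5 ug/mL as the highest. Compound 4 `CCCCCCCCC(=O)c1c(O)cc(O)c([C@@H](CC(C)C)C2=C(O)C(C)(C)C(=O)C(C)(C)C2=O)c1O` differs from compound 1 by hydrogen in place of methyl on a saturated chain carbon, eight bonds along the chain from a carbonyl carbon with hydrogen in place of methyl on a saturated chain carbon, eight bonds along the chain from a carbonyl carbon. The nearest evidence is no change at the digits printed from compound 1 to compound 2 (within the scatter) for a larger cut of the same chain, whereas a 3.4-fold higher number from compound 1 to compound 3 (0.54 log units; beyond the scatter) and a 3.4-fold higher number from compound 2 to compound 3 (0.54 log units; beyond the scatter) come only with a far longer chain. No shift beyond the scatter is therefore expected in this assay, and the estimated no change at the digits printed from compound 1 to compound 4 (within the scatter) stays small. For compound 4 the expected value is 5.1 ug/mL (estimated range 3 ug/mL to 8.5 ug/mL).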

Compound 4, half-maximal inhibitory concentration: 8.2 ug/mL
Estimate against measurement, compound 4: 1.6-fold (0.21 log units) below, and the stated range covers the measured number.
By their numbers in this assay, from the lowest: compounds 1, 2 and 4 (each within the scatter of the next); then compound 3.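

Hydrogen in place of methyl, eight bonds along the chain from a carbonyl carbon, gives a 1.6-fold higher number from compound 1 to compound 4 (0.21 log units; within the scatter) in this assay and methyl in place of hydrogen, seven bonds along the chain, gives a 1.6-fold higher number from compound 2 to compound 4 (0.21 log units; within the scatter) so this single-carbon change does not separate these three chains. The step of a 2.1-fold lower number from compound 3 to compound 4 (0.33 log units; beyond the scatter) is beyond the scatter, so compound 4 joins compounds 1 and 2 in standing apart from compound 3. Nothing on hand accounts for these numbers.

Where between the chains of compound 1 and compound 3 the number begins to climb stays open. So does the reading of a terminal amine or carboxylic acid on the chain.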